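A few compounds are considered here, and "the series" means these few. Any claim that something is new, unique, unknown or untested is made for them only; others in the source may bear on it.

Measured compounds:
compound 1, `CCc1nc2ccccc2c(=O)n1NC(=O)Nc1ccc(Br)cc1` — 54%
compound 2, `CCc1nc2ccccc2c(=O)n1NC(=O)Nc1ccc(OC)cc1` — 48%

Among the compounds with values here, in a functional assay on the whole organism (strain albino) with Mus musculus as the target, at a dose of 100 mg/kg by the intraperitoneal route (a lower number here means less inhibition, a higher number more inhibition at the dose given (going by the name of the read-out)), compound 2 gives 48%, the lower of the two numbers so far; compound 1 gives 54%, and the step of a number 6 percentage points lower from compound 1 to compound 2 (within the scatter) lies within the scatter, so the two compounds cannot be separated on these data. Compound 3, `CCc1nc2ccccc2c(=O)n1NC(=O)Nc1ccc(I)cc1`, is not yet measured. It differs from compound 2 in a single place: iodo in place of methoxy on an aromatic carbon. Within the data shown here, the one measured step that bears on this change, a number 6 percentage points lower from compound 1 to compound 2 (within the scatter), put methoxy in place of bromo without any shift beyond the scatter; the change to compound 3 runs the other way and brings in a halogen again. On that basis the expected step, a number 4 percentage points higher from compound 2 to compound 3 (within the scatter), stays within the scatter, with no clear direction. Compound 3 is estimated at 52%, with a range from 36% to 68%.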

Compound 3, a percentage reported as inhibition, in the whole organism at one dose (the size of the read-out at that dose, not a potency): 55%
Compound 3: the middle estimate sits 3 percentage points below what was measured, within the range that was stated.
By their numbers in this assay, from the lowest: compounds 2, 1 and 3 (each within the scatter of the next).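

In this assay, iodo in place of methoxy on this aromatic carbon gives a number 7 percentage points higher from compound 2 to compound 3 (within the scatter), so a second halogen at this place also stays within the scatter of the methoxy compound. Within the data shown here, the exchange of one halogen for the other, iodo in place of bromo, gives a number 1 percentage points higher from compound 1 to compound 3 (within the scatter), so bromo, iodo and methoxy at this place cannot be separated at this single dose, and the series so far shows no dependence on which of these three groups is present. Nothing at hand bears on the reason for this flat result.

From the compounds shown here alone, whether this place responds to any group at all stays open, since an amine, a carboxylic acid or a longer alkoxy chain could still move the number beyond the scatter. Single-dose numbers also leave any difference in potency among these compounds unresolved.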